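Methyl for trifluoromethyl on two amide-linked cores

A few compounds are considered here, and "the series" means these few. Any claim that something is new, unique, unknown or untested is made for them only; others in the source may bear on it.

Compound 1 `Cc1ccc(C(=O)Nc2nc(Cl)c3cn(C(C)C)nc3n2)cc1`: > 20000 nM
Compound 2 `CC(C)n1cc2c(Cl)nc(NC(=O)c3ccc(C(F)(F)F)cc3)nc2n1`: > 20000 nM
Compound 3 `CCOC(=O)c1nc(NC(=O)c2ccc(C(F)(F)F)cc2)nc2nn(CC(C)(C)C)cc12`: > 20000 nM

Three compounds were tested in a functional assay on CHO cells for antagonist activity at adenosine receptor A2b (Homo sapiens), read by 33P incorporation, with a stated time of 20 min, in the presence of a further agent that is not named here; on this read-out higher numbers stand for weaker inhibition and lower numbers for stronger inhibition. Compound 1 `Cc1ccc(C(=O)Nc2nc(Cl)c3cn(C(C)C)nc3n2)cc1` gives only the limit > 20000 nM in this assay. Compound 2 `CC(C)n1cc2c(Cl)nc(NC(=O)c3ccc(C(F)(F)F)cc3)nc2n1` likewise gives only the limit > 20000 nM. Compound 3 `CCOC(=O)c1nc(NC(=O)c2ccc(C(F)(F)F)cc2)nc2nn(CC(C)(C)C)cc12` also stops at the limit > 20000 nM. All three sit at the limit of > 20000 nM in this assay, at which 3 of the 3 values shown sit.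

Compound 1 differs from compound 2 by methyl in place of trifluoromethyl on an aromatic carbon; the step that the two limits leave unreadable from compound 2 to compound 1 cannot be read because both ends are limits. Compound 4 `CCOC(=O)c1nc(NC(=O)c2ccc(C)cc2)nc2nn(CC(C)(C)C)cc12` is made from compound 3 by methyl in place of trifluoromethyl on an aromatic carbon, the same change at the same place. The cores of compound 2 and compound 3 differ in a way not broken down here.

Compound 4 is expected to stay near the limit, with an estimated step that the limit leaves unreadable from compound 3 to compound 4 from compound 3, because compound 2 and compound 1 both sit at the limit of > 20000 nM in this assay, at which 3 of the 3 values shown sit, and compound 3 gives only a limit > 20000 nM. The estimate for compound 4 is 30000 nM, expected to lie between 8000 nM and 100000 nM, most likely reported again as a limit.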

Compound 4, inhibition constant: > 20000 nM
Compound 4: no number, only a limit (the forecaster's own chance of this, stated with the estimate: 85%); the middle value is on the limit's open side.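

No step can be read from compound 3 to compound 4, because the values of both are limits and not numbers: the limit of > 20000 nM in this assay, at which 4 of the 4 values shown sit. The compounds shown leave open how strongly any of them inhibits in this assay, and whether methyl in place of trifluoromethyl makes any difference on either core.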